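This account rests on a few compounds, and the source may have more. Where it says the series, first, only, none or still open, it means among the compounds named here.

Three amides of the shared core have numbers in a functional assay on NIH3T3 cells for agonist activity at Urotensin-2 receptor (Homo sapiens), with a stated time of 5 days; on this read-out lower numbers stand for an effect already at smaller amounts and higher numbers for an effect only at larger amounts of compound. Compound 1 `Cc1ccc(C(CCN(C)C)NC(=O)CCc2ccccc2)cc1` gives 4570 nM; compound 2 `COc1ccc(CCC(=O)NC(CCN(C)C)c2ccc(Cl)cc2)cc1` gives 2950 nM; compound 3 `CN(C)CCC(NC(=O)CCc1ccccc1)c1ccc(Cl)cc1` gives 1660 nM. Compound 1 thus has the highest of the three numbers; its gap to compound 2 lies within the scatter, while the step of a 2.8-fold lower number from compound 1 to compound 3 (0.44 log units; beyond the scatter) lies beyond it. The step of a 1.8-fold lower number from compound 2 to compound 3 (0.25 log units; within the scatter) stays within the scatter.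

Compound 4 `Cc1ccc(C(CCN(C)C)NC(=O)C#Cc2ccccc2)cc1` differs from compound 1 in one place: 2-phenylethynyl in place of phenethyl on a carbonyl carbon. Neither measured step bears on this change: the step from compound 1 to compound 3 swaps groups on an aromatic carbon, the step from compound 2 to compound 3 does the same on the other ring, and neither touches the carbonyl carbon. Among the compounds with values here, with no step to lean on, no direction beyond the scatter is expected, and the number of compound 4 is expected near that of compound 1, with a wide range. The expected step is a 1.1-fold higher number from compound 1 to compound 4 (0.04 log units; within the scatter). Compound 4 is therefore estimated at 5000 nM, between 1500 nM and 16000 nM.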

Compound 4, half-maximal effective concentration: 3090 nM
For compound 4 the middle estimate is 1.6-fold (0.21 log units) above the measured one; the measured number falls inside the stated range.
By their numbers in this assay, from the lowest: compounds 3, 2, 4 and 1 (each within the scatter of the next, the first and the last beyond it).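

Within the data shown here, this is the first step at the carbonyl carbon, as the earlier steps all changed groups on an aromatic carbon. In this assay, 2-phenylethynyl in place of phenethyl gives a 1.5-fold lower number from compound 1 to compound 4 (0.17 log units; within the scatter), so this single pair shows that introducing a triple bond outside aromatic rings at this place leaves the number within the scatter. No available measurement connects this result to any property of either group.

The compounds shown leave open whether the same swap stays within the scatter on the chloro-bearing core of compound 3, since this pair carries the methyl group. They also leave open how the number responds at this carbonyl carbon to a group of a different kind, such as a longer chain ending in phenyl, a benzyl group or an amine.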